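Replacing fluoro with bromo on the shared core

A few compounds are considered here, and "the series" means these few. Any claim that something is new, unique, unknown or untested is made for them only; others in the source may bear on it.

In a functional assay on Hs68 cells (Homo sapiens) for inhibition (on this read-out lower numbers stand for higher toxicity in this test and higher numbers for lower toxicity in this test), compound 1 `COc1ccccc1CNC(=O)c1ccc2c(F)nccc2n1` gives about 10 ug/mL, and compound 2 `COc1ccccc1CNC(=O)c1ccc2c(N)nccc2n1` gives about 12.5 ug/mL, so the two lie within the scatter of each other. Compound 3 `COc1ccccc1CNC(=O)c1ccc2c(OC)nccc2n1` gives > 50 ug/mL, which is a limit of the assay and not a number. Compound 4 `COc1ccccc1CNC(=O)c1ccc2c(Br)nccc2n1` differs from compound 1 by having bromo in place of fluoro on an aromatic carbon, next to the ring nitrogen (bromo in place of fluoro on an aromatic carbon). Two measured changes start from that same fluoro: amino gave a 1.3-fold higher number from compound 1 to compound 2 (0.10 log units; within the scatter), while methoxy gave an at least 5.0-fold higher number from compound 1 to compound 3 (0.69 log units; beyond the scatter). Neither brings in another halogen, so they are only a loose guide. The estimated step is a 1.3-fold higher number from compound 1 to compound 4 (0.11 log units; within the scatter), so no shift beyond the scatter is expected in this assay. For compound 4 the expected value is 13 ug/mL, with a likely range from 5 ug/mL to 35 ug/mL.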

Compound 4, half-maximal cytotoxic concentration: about 25 ug/mL
The estimate for compound 4 lay 1.9-fold (0.28 log units) below the measured number; low and high end bracket the measured number.
By their numbers in this assay, from the lowest: compounds 1, 2 and 4 (each within the scatter of the next, the first and the last beyond it). At a limit, above all of these: compound 3.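

In this assay, exchanging one halogen for another at this position is enough to move the result, with a 2.5-fold higher number from compound 1 to compound 4 (0.40 log units; beyond the scatter). The step from amino to bromo lies within the scatter, with a 2.0-fold higher number from compound 2 to compound 4 (0.30 log units; within the scatter). The step that starts from methoxy can be given only as a floor, with an at least 2.0-fold lower number from compound 3 to compound 4 (0.30 log units; that floor lies within the scatter). Compound 3 stands at a limit of the assay: the limit of > 50 ug/mL in this assay, at which 1 of the 4 values shown sits.

Left open is where chloro, another halogen, or ethoxy, a longer chain than methoxy, would fall at this position. The compounds shown also leave open whether the step from fluoro to bromo would hold on a different core.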